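Adding chloro to compound 2: working notes

The compounds below may be only part of what the source reports. "The series", "measured", "known", "first", "only" and "open" are said of these compounds alone.

Measured in a functional assay on DU-145 cells (Homo sapiens) for antiproliferative activity, read by sulforhodamine B assay, with a stated time of 72 h; a higher number here means a weaker inhibitor, a lower number a stronger inhibitor:
- compound 1 `O=C1CS/C(=N/Nc2nncc3ccccc23)N1c1ccccc1`: 97 nM
- compound 2 `C(=C/c1ccccc1)\C(=N\Nc1nncc2ccccc12)c1ccccc1`: 1.3 nM

Of the two, compound 2, at 1.3 nM, gives the lower number, beyond the scatter from compound 1. Compound 3 `Clc1ccc(C(/C=C/c2ccccc2)=N\Nc2nncc3ccccc23)cc1` has chloro in place of hydrogen on an aromatic carbon, para to a large group, phenyl to 4-chlorophenyl (chloro in place of hydrogen on an aromatic carbon). Among the compounds with values here, no measured step covers this change, so the expectation is loose. The expected step is a 1.8-fold higher number from compound 2 to compound 3 (0.27 log units; within the scatter), slightly weaker in this assay but not beyond the scatter. The estimate for compound 3 is 2.4 nM, with a range of 0.5 nM to 12 nM.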

Compound 3, half-maximal inhibitory concentration: 4.6 nM
Estimate against measurement, compound 3: 1.9-fold (0.28 log units) below; the range from low to high includes it.
By their numbers in this assay, from the lowest: compound 2; then compound 3; then compound 1.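

In this assay, within the data shown here, chloro in place of hydrogen on an aromatic carbon, para to a large group, gives a 3.5-fold higher number from compound 2 to compound 3 (0.55 log units; beyond the scatter), the first measured step at this position. The change from phenyl to 4-chlorophenyl therefore has a modest but real cost here, and compound 3 still reads 4.6 nM. Nothing available accounts for this step.

Going by these compounds, whether fluoro, methoxy or an amine at this place would give a similar step remains open. So does whether the chloro step carries over to other positions on the series.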